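Para-substituent swap on the piperidine series: pyrrolyl to trifluoromethyl

The source may report more compounds than this note shows. Statements on the series, on what has been measured and on what is new or still open speak of the compounds shown alone.

Three compounds have numbers in an assay for inhibition of protein disulfide-isomerase (Homo sapiens), with a stated time of 1 h; on this read-out lower numbers stand for stronger inhibition and higher numbers for weaker inhibition. Compound 1 `Cc1ccc(C)c(C(Nc2ccccn2)c2ccc3cccnc3c2O)c1` gives 730 nM. Among the measured compounds shown here, compound 3 `COc1cccc(C(Nc2ccccn2)c2ccc3cccnc3c2O)c1` gives 2860 nM, and the only single-point step among the measured pairs, a 3.9-fold higher number from compound 1 to compound 3 (0.59 log units; beyond the scatter), is a modest loss. Compound 2 `Oc1ccc2[nH]ncc2c1C(c1ccc(-n2cccc2)cc1)N1CCCCC1` gives 290 nM, the lowest of the three numbers; its gap to compound 1 and its larger gap to compound 3 are both beyond the scatter, so compound 2 is the most potent of the set in this assay.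

Compound 4 `Oc1ccc2[nH]ncc2c1C(c1ccc(C(F)(F)F)cc1)N1CCCCC1` differs from compound 2 in one place: trifluoromethyl in place of 1H-pyrrol-1-yl on an aromatic carbon. The group that leaves is one five-membered aromatic ring with one hetero atom; the group that enters has no ring. For the measured compounds named here, no measured step touches this position. The step from compound 1 to compound 3 exchanges the aryl group on the saturated chain carbon, a different place, and only shows that a single aryl change here can move this assay by a modest amount. Going by the values given here, with no step of the same kind on record, a small loss is expected rather than a gain, with wide uncertainty. Compound 4 is therefore estimated at 550 nM, between 170 nM and 1800 nM, an expected step of a 1.9-fold higher number from compound 2 to compound 4 (0.28 log units; within the scatter).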

Compound 4, half-maximal inhibitory concentration: 710 nM
Compound 4: middle estimate off by 1.3-fold (0.11 log units), on the low side, and the stated range covers the measured number.
By their numbers in this assay, from the lowest: compound 2; then compounds 4 and 1 (each within the scatter of the next); then compound 3.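

In this assay, this aromatic carbon, para to a large group, now has its first reading, and the position is sensitive to the exchange: trifluoromethyl in place of 1H-pyrrol-1-yl gives a 2.4-fold higher number from compound 2 to compound 4 (0.39 log units; beyond the scatter). The loss is modest, and compound 4 still reads 710 nM with no ring and no hydrogen-bond acceptor in the entering group, so the aromatic ring of 1H-pyrrol-1-yl is not needed for measurable inhibition on this core. No supporting data bear on the cause of this step.

The two groups differ at once in ring content, heavy-atom count and hydrogen-bond acceptor count, so the step cannot be assigned to any one of these differences. On these data alone, a phenyl ring, an amine or a carboxylic acid on the same aromatic carbon would help to separate them, and how such groups read in this assay remains open, as does whether the same exchange would have a similar effect on another core.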